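Piperidin-1-yl on the chain: an expected toxicity

A few compounds are considered here, and "the series" means these few. Any claim that something is new, unique, unknown or untested is made for them only; others in the source may bear on it.

In a toxicity assay on L02 cells (Homo sapiens) for cytotoxicity, read by MTT assay, with a stated time of 72 h (on this read-out higher numbers stand for weaker inhibition and lower numbers for stronger inhibition), compound 1 (`O=C1c2c[n+]([O-])c3ccccc3c2C(=O)c2c1c1ccccc1n2CCCCn1ccnc1`) gives 150 nM, compound 2 (`O=C1c2c[n+]([O-])c3ccccc3c2C(=O)c2c1c1ccccc1n2CCN1CCCC1`) gives 930 nM and compound 3 (`O=C1c2c[n+]([O-])c3ccccc3c2C(=O)c2c1c1ccccc1n2CCCCN1CCNCC1`) gives 1380 nM. The measured steps are a 9.2-fold higher number from compound 1 to compound 3 (0.96 log units; beyond the scatter) and a 1.5-fold higher number from compound 2 to compound 3 (0.17 log units; within the scatter). Compound 3 thus shares its level with compound 2, while compound 1 stands apart.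

Compound 4 (`O=C1c2c[n+]([O-])c3ccccc3c2C(=O)c2c1c1ccccc1n2CCN1CCCCC1`) differs from compound 3 as follows: piperidin-1-yl in place of 2-(piperazin-1-yl)ethyl on a saturated chain carbon, two bonds along the chain from an aromatic nitrogen. The swap sits on a saturated chain carbon, two bonds along the chain from an aromatic nitrogen. The step at that same place, between compound 2 and compound 3, stayed within the scatter, so it is the best guide. The larger steps, such as a 6.2-fold higher number from compound 1 to compound 2 (0.79 log units; beyond the scatter), leave the 1H-imidazol-1-yl group, which compound 3 lacks.

In this assay, the expected result is a 1.5-fold lower number from compound 3 to compound 4 (0.19 log units; within the scatter), no real change. Compound 4 is estimated at 900 nM, within an expected range of 350 nM to 2300 nM.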

Compound 4, half-maximal inhibitory concentration: 1050 nM
Compound 4: the middle estimate sits 1.2-fold (0.07 log units) below what was measured; low and high end bracket the measured number.
By their numbers in this assay, from the lowest: compound 1; then compounds 2, 4 and 3 (each within the scatter of the next).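

In this assay, the step from 2-(piperazin-1-yl)ethyl to piperidin-1-yl (a 1.3-fold lower number from compound 3 to compound 4 (0.12 log units; within the scatter)) and the step from pyrrolidin-1-yl to piperidin-1-yl (a 1.1-fold higher number from compound 2 to compound 4 (0.05 log units; within the scatter)) show that these three groups share one level at this place. Compound 1, with its 2-(1H-imidazol-1-yl)ethyl group, stays apart (a 7.0-fold higher number from compound 1 to compound 4 (0.85 log units; beyond the scatter)). Nothing measured here explains this level or this gap.

The compounds shown leave open whether morpholin-4-yl or an open-chain dimethylamino group would stay at the level of compound 4 or come closer to compound 1.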